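Carboxy to hydroxymethyl on a quinone chain terminus

The source may report more compounds than this note shows. Statements on the series, on what has been measured and on what is new or still open speak of the compounds shown alone.

Measured compounds:
Compound 1 `COC1=C(OC)[C@H](OC(C)=O)[C@H](C/C=C(\C)CC/C=C(\C)C[C@H](O)/C=C(\C)C(=O)O)[C@@H](C)C1=O`: in a functional assay on A549 cells (Homo sapiens) for inhibition, read by sulforhodamine B assay, with a stated time of 48 h (a lower number here means a stronger inhibitor of growth, a higher number a weaker inhibitor of growth), compound 1 gives a limit of > 30000 nM rather than a number.
Compound 2 `COC1=C(OC)[C@H](O)[C@H](C/C=C(\C)CC/C=C(\C)CCC=C(C)C)[C@@H](C)C1=O`: compound 2 gives 5700 nM.
Compound 3 `COC1=C(OC)[C@H](O)[C@H](C/C=C(\C)CC/C=C(\C)C/C=C/C(C)(C)O)[C@@H](C)C1=O`: compound 3 gives 23800 nM.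

Compound 1 stands at the limit of this assay, as noted in the limit of > 30000 nM in this assay, at which 1 of the 3 values shown sits, so its own position on the scale is known only as a limit and not as a number. Compound 4 `COC1=C(OC)[C@H](OC(C)=O)[C@H](C/C=C(\C)CC/C=C(\C)C[C@H](O)/C=C(\C)CO)[C@@H](C)C1=O` is the compound still to be measured. It differs from compound 1 in one place: hydroxymethyl in place of carboxy on a double-bonded chain carbon bound to a double-bonded chain carbon and a saturated chain carbon.

Only one measured step exists among the compounds shown, a 4.2-fold higher number from compound 2 to compound 3 (0.62 log units; beyond the scatter), and it concerns a different part of the chain and a different pair of groups than the change from compound 1 to compound 4. For the measured compounds named here, it therefore offers no direct guide to the present change, and nothing among the measured compounds tells how the carboxy itself sets the number.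

With compound 1 at the limit, any estimate for compound 4 rests on little. Compound 4 is expected to remain a weak inhibitor in this assay, with an estimate of 25000 nM and a range from 8000 nM to 60000 nM. The step this estimate implies, an at least 1.2-fold lower number from compound 1 to compound 4 (0.07 log units; that floor lies within the scatter), is expected to be small, and a second limit is about as likely as a number.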

Compound 4, concentration for 50% growth inhibition: 29000 nM
The estimate for compound 4 lay 1.2-fold (0.06 log units) below the measured number; the range from low to high includes it.
By their numbers in this assay, from the lowest: compound 2; then compounds 3 and 4 (each within the scatter of the next). At a limit, above all of these: compound 1.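

In this assay compound 1 gives > 30000 nM, which is a limit of the assay and not a number. With hydroxymethyl in place of carboxy, compound 4 gives 29000 nM, so this position now carries a value that can be placed on the scale, and the change does not take the number out of the range of this assay. The change can be read only as an at least 1.0-fold lower number from compound 1 to compound 4 (0.01 log units; that floor lies within the scatter), and its true size stays unknown because one end of the step is not a number: the limit of > 30000 nM in this assay, at which 1 of the 4 values shown sits.

The compounds shown do not tell how far the value of compound 1 lies past its limit, so the step could be small or large, and they give no reading of how the carboxy or the hydroxymethyl sets the number. They also leave open whether a methyl ester, an amine or a longer chain on this double-bonded chain carbon would move the number in this assay, and whether the same exchange would give a similar step on another form of the shared core.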